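Hydroxy in Place of Vinyl Across Two Cores

The compounds below may be only part of what the source reports. "The series", "measured", "known", "first", "only" and "open" are said of these compounds alone.

Compound 1, `C=Cc1ccc(S(=O)(=O)Nc2ccc3oc(-c4ccccc4)nc3c2)cc1`, reaches only a limit in an assay on isolated protein for inhibition of malate dehydrogenase, mitochondrial (Sus scrofa), with stated times of 45 min and 30 min; on this read-out higher numbers stand for weaker inhibition and lower numbers for stronger inhibition: > 63000 nM.
Compound 2, `C=Cc1ccc(S(=O)(=O)Nc2ccc(-c3nc4ccccc4o3)cc2)cc1`, likewise gives only a limit: > 63000 nM.
Compound 3, `O=S(=O)(Nc1ccc2oc(-c3ccccc3)nc2c1)c1ccc(O)cc1`, also stays at a limit: > 63000 nM.

All three measured values sit at the limit of > 63000 nM in this assay, at which 3 of the 3 values shown sit, so none of them is a number. For the measured compounds named here, the one change that can be followed between measured compounds is hydroxy in place of vinyl on an aromatic carbon; the step it made is a step that the two limits leave unreadable from compound 1 to compound 3, and because both ends are limits the limit of > 63000 nM in this assay, at which 3 of the 3 values shown sit, the size of that step cannot be read. How the core of compound 1 and the core of compound 2 differ is not broken down here; the two have the same atoms joined differently.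

Compound 4, `O=S(=O)(Nc1ccc(-c2nc3ccccc3o2)cc1)c1ccc(O)cc1`, has not yet been measured. It differs from compound 2 by hydroxy in place of vinyl on an aromatic carbon, the same change that was made from compound 1 to compound 3, at a place described in the same words. Going by the values given here, since compound 2 itself shows only a limit, > 63000 nM, and the one earlier instance of this change, a step that the two limits leave unreadable from compound 1 to compound 3, left no readable size, the expectation for compound 4 rests on weak ground. Compound 4 is expected to remain near the limit, at an estimated 100000 nM, within 40000 nM to 300000 nM. The step so expected is a step that the limit leaves unreadable from compound 2 to compound 4.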

Compound 4, half-maximal inhibitory concentration: > 63000 nM
Compound 4 gave a limit, no number; the forecaster's own chance of this, stated with the estimate: 85%; the middle value does not contradict the limit.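

In this assay compound 4 gives > 63000 nM which is a limit and not a number, so no new step can be read from compound 2 to compound 4, and compound 1 and compound 3 remain just as unreadable: the limit of > 63000 nM in this assay, at which 4 of the 4 values shown sit.

The compounds shown leave open whether hydroxy in place of vinyl changes inhibition at all on either core, and whether the two cores differ.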